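The source may report more compounds than this note shows. Statements on the series, on what has been measured and on what is new or still open speak of the compounds shown alone.

The three measured compounds, with their numbers in a functional assay on ECV-304 cells (Homo sapiens), read by MTT assay, with stated times of 24 h and 12 h, tested at 50 uM; on this read-out lower numbers stand for a weaker effect and higher numbers for a stronger effect at the one concentration tested:

Compound 1 `COC(=O)c1ccc(OCc2nc(C)c(C)nc2C)c(OC)c1`: 15.8%
Compound 2 `Cc1nc(C)c(COc2ccccc2C(=O)O)nc1C`: 18.2%
Compound 3 `C=CCSSCc1nc(C)c(C)nc1C`: 15%

All three numbers lie close together. Compound 1 gives 15.8%, and compound 3 with 15% and compound 2 with 18.2% each sit within the usual scatter of it, so nothing among these three can be ranked. For the measured compounds named here, no pair of them differs in only one place, and so no single step can be read from the measured set.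

Compound 4 `C=CCc1ccc(OCc2nc(C)c(C)nc2C)c(OC)c1` has not yet been measured in this assay . It is reached from compound 1 by one change: allyl in place of methoxycarbonyl on an aromatic carbon. Nothing in the measured compounds shows how such a change at this place bears on this assay . Since the three measured compounds, which differ widely in their substituents, all give numbers within the scatter of one another, the step from compound 1 to compound 4 is expected to be small, with no clear direction, and is estimated as a number 0.2 percentage points higher from compound 1 to compound 4 (within the scatter). Compound 4 is therefore expected to give about 16%, within a range from 5% to 30%.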

Compound 4, a percentage reported as activity, at one concentration (the size of the read-out at that concentration, not a potency): 30.1%
Estimate against measurement, compound 4: 14.1 percentage points below; measured number above the stated range.
By their numbers in this assay, from the lowest: compounds 3, 1 and 2 (each within the scatter of the next); then compound 4.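

In this assay, the aromatic carbon para to a large group and meta to a methoxy group proves not to be indifferent: allyl in place of methoxycarbonyl gives a number 14.3 percentage points higher from compound 1 to compound 4 (beyond the scatter). For the compounds shown here, this is the first step that can be read at a single place, and it lies beyond the scatter, whereas the earlier numbers could not be ranked and no pair among them differed in only one place. Methoxycarbonyl carries 2 hydrogen-bond acceptors and allyl carries none, but no measurement shown explains the step.

One step cannot tell whether the higher number comes from the arrival of allyl or the departure of methoxycarbonyl. As far as these compounds go, it also remains open how a propyl chain, a carboxylic acid or an amine on this same carbon would read out.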